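This account rests on a few compounds, and the source may have more. Where it says the series, first, only, none or still open, it means among the compounds named here.

Values in a functional assay on S1 cells (Homo sapiens) for cytotoxicity, read by MTT assay, with a stated time of 72 h; on this read-out lower numbers stand for stronger inhibition and higher numbers for weaker inhibition:
compound 1 `COc1ccc(/C=C/c2cc(C)no2)cc1OC`: > 100000 nM, a limit and not a number
compound 2 `Cc1cc(/C=C/c2ccc(O)c(O)c2)on1`: 7900 nM
compound 3 `COc1ccc(/C=C/c2cc(C)no2)cc1`: 76400 nM

Of the two true numbers, compound 3 is the higher at 76400 nM, and compound 2 lies lower at 7900 nM, a gap beyond the scatter.

The next compound is compound 4 `Cc1cc(/C=C/c2ccc(O)cc2)on1`. The change from compound 3 is hydrogen in place of methyl on an oxygen on an aromatic ring, or methoxy to hydroxy.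

Among the compounds with values here, only one measured step is close to this: an at least 1.3-fold lower number from compound 1 to compound 3 (0.11 log units; that floor lies within the scatter). It removes a whole methoxy rather than the methyl of one, and its size is only a floor, so it gives little guidance. The better guide is compound 2, which bears hydroxy groups and reads 7900 nM. A step to a lower number is therefore expected in this assay, probably stopping short of that value. The expected step is a 3.1-fold lower number from compound 3 to compound 4 (0.49 log units; beyond the scatter). The estimate for compound 4 is 25000 nM, with an expected range of 9000 nM to 70000 nM.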

Compound 4, half-maximal inhibitory concentration: 44200 nM
Beside the measured number, compound 4's estimate is 1.8-fold (0.25 log units) below it; the range from low to high includes it.
By their numbers in this assay, from the lowest: compound 2; then compounds 4 and 3 (each within the scatter of the next). At a limit, above all of these: compound 1.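

In this assay, methoxy to hydroxy on its own, at a single oxygen on the aromatic ring, does not move the number beyond the scatter (a 1.7-fold lower number from compound 3 to compound 4 (0.24 log units; within the scatter)). The step that does lie beyond the scatter is the removal of one hydroxy from the aromatic ring (a 5.6-fold higher number from compound 2 to compound 4 (0.75 log units; beyond the scatter)), so the low number of compound 2 is lost when only one of its two hydroxy groups remains. Nothing measured here gives a cause for either step.

Still open, as far as these compounds go, is whether a hydroxy is specifically required, since no amine or carboxylic acid stands on the aromatic ring in its place. The methyl on the carbon of the shared core is also constant across all four compounds, leaving the effect of a longer chain there unknown.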